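The source may report more compounds than this note shows. Statements on the series, on what has been measured and on what is new or still open speak of the compounds shown alone.

In a functional assay on Bel-7402 cells (Homo sapiens) for antiproliferative activity, read by MTT assay, with a stated time of 72 h (on this read-out higher numbers stand for weaker inhibition and lower numbers for stronger inhibition), compound 1 `C=C1C(=O)O[C@H]2[C@H]1CC/C(COC(=O)Cn1cc(F)c(=O)[nH]c1=O)=C\CC[C@@]1(C)O[C@@H]21` gives only a limit, > 20000 nM. Compound 2 `C=C1C(=O)O[C@H]2[C@H]1CC/C(COC(=O)Cn1cc(F)c(=O)n(Cc3ccc(F)cc3)c1=O)=C\CC[C@@]1(C)O[C@@H]21` carries a 4-fluorobenzyl group in place of hydrogen on an aromatic nitrogen and gives 2730 nM. Compound 3 `C=C1C(=O)O[C@H]2[C@H]1CC/C(COC(=O)Cn1cc(F)c(=O)n(Cc3cccc(F)c3)c1=O)=C\CC[C@@]1(C)O[C@@H]21` carries a 3-fluorobenzyl group there and gives 2530 nM. Adding these groups produced large steps: an at least 7.3-fold lower number from compound 1 to compound 2 (0.86 log units; beyond the scatter), and an at least 7.9-fold lower number from compound 1 to compound 3 (0.89 log units; beyond the scatter). Compound 3 therefore stands level with compound 2, as the comparison between them shows a 1.1-fold lower number from compound 2 to compound 3 (0.03 log units; within the scatter), and both have real numbers where compound 1 has only a limit.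

Compound 4 `C=C1C(=O)O[C@H]2[C@H]1CC/C(COC(=O)Cn1cc(F)c(=O)n(Cc3ccc(F)c(F)c3)c1=O)=C\CC[C@@]1(C)O[C@@H]21` keeps this design and adds one atom to the ring: fluoro in place of hydrogen on an aromatic carbon. This is fluoro in place of hydrogen on an aromatic carbon, turning 3-fluorobenzyl into 3,4-difluorobenzyl. The large steps from compound 1 involve adding a whole benzyl group, so they say little about a single extra fluoro. The closest guide is the shift of the fluoro between compound 2 and compound 3, which gave only a 1.1-fold lower number from compound 2 to compound 3 (0.03 log units; within the scatter). On that basis, no change beyond the scatter is expected in this assay, and the expected step is a 1.1-fold lower number from compound 3 to compound 4 (0.02 log units; within the scatter). For compound 4 the estimated value is 2400 nM, with an expected range from 1200 nM to 5000 nM.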

Compound 4, half-maximal inhibitory concentration: 2700 nM
The estimate for compound 4 lay 1.1-fold (0.05 log units) below the measured number; measured number inside the range.
By their numbers in this assay, from the lowest: compounds 3, 4 and 2 (each within the scatter of the next). At a limit, above all of these: compound 1.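

In this assay, a second fluoro on the six-membered aromatic ring, ortho to the first fluoro and para to a large group, leaves the number within the scatter: a 1.1-fold higher number from compound 3 to compound 4 (0.03 log units; within the scatter), and a 1.0-fold lower number from compound 2 to compound 4 (0.00 log units; within the scatter). The earlier compounds shown here showed only that one fluoro could sit at either of two places on the benzyl group, whereas compound 4 shows that an added fluoro also makes no readable difference, so compounds 2, 3 and 4 stand level. The large gain over the compound with hydrogen on the aromatic nitrogen also holds for 3,4-difluorobenzyl, an at least 7.4-fold lower number from compound 1 to compound 4 (0.86 log units; beyond the scatter), but that step gives only a minimum size, as compound 1 gives a limit and not a number: the limit of > 20000 nM in this assay, at which 1 of the 4 values shown sits.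

On these data alone, with only fluoro varied on this ring, it remains open whether a chloro, methoxy, nitrile or trifluoromethyl group at the same carbon would move the number beyond the scatter. As far as these compounds go, it also remains open whether the benzyl group itself is needed for the gain, or whether a plain methyl or a longer alkyl chain on that nitrogen would give a similar step.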